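Swapping pyridin-4-yl for 4-methylphenyl on a saturated carbon

The source may report more compounds than this note shows. Statements on the series, on what has been measured and on what is new or still open speak of the compounds shown alone.

Measured in a functional assay on B16-F10 cells (Mus musculus) for antiproliferative activity, read by MTT assay, with a stated time of 48 h; a higher number here means a weaker inhibitor, a lower number a stronger inhibitor:
compound 1 `CC(=O)N1N=C(c2ccc3ccccc3c2)OC1c1cccc(F)c1` gives 1.61 ug/mL
compound 2 `CC(=O)N1N=C(c2ccc3ccccc3c2)OC1c1ccncc1` gives 2.97 ug/mL

Among the compounds with values here, compound 2 lies within the scatter of compound 1, its only neighbour on the scale so far. Compound 3 `CC(=O)N1N=C(c2ccc3ccccc3c2)OC1c1ccc(C)cc1` differs from it in one group: 4-methylphenyl in place of pyridin-4-yl on a saturated ring carbon. Within the data shown here, the only measured step that bears on this, a 1.8-fold higher number from compound 1 to compound 2 (0.27 log units; within the scatter), also exchanged one aromatic ring for another on a saturated ring carbon. With so small a precedent, no shift beyond the scatter is expected in this assay, and no firm direction. The estimated change is a 1.4-fold lower number from compound 2 to compound 3 (0.13 log units; within the scatter). Compound 3 is expected at 2.2 ug/mL, with an estimated range of 1 ug/mL to 4.7 ug/mL.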

Compound 3, half-maximal inhibitory concentration: 3.85 ug/mL
The estimate for compound 3 lay 1.8-fold (0.24 log units) below the measured number, and the stated range covers the measured number.
By their numbers in this assay, from the lowest: compounds 1, 2 and 3 (each within the scatter of the next, the first and the last beyond it).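

In this assay, 4-methylphenyl in place of pyridin-4-yl gives a 1.3-fold higher number from compound 2 to compound 3 (0.11 log units; within the scatter) and so does not separate these two rings. Within the data shown here, the saturated ring carbon still responds to the choice of ring: 4-methylphenyl in place of 3-fluorophenyl gives a 2.4-fold higher number from compound 1 to compound 3 (0.38 log units; beyond the scatter) and this is the first modest step beyond the scatter. No evidence here explains that step. Still open, on these data alone, is whether a carboxylic acid or an amine on the ring, or a longer chain in place of the ring, would move the number further.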